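The source may report more compounds than this note shows. Statements on the series, on what has been measured and on what is new or still open speak of the compounds shown alone.

The measured compounds:

Compound 1, `COc1ccc(-c2ncnn2-c2cc(OC)c(OC)c(OC)c2)cc1`: 50 nM
Compound 2, `CCOc1ccc(-c2ncnn2-c2cc(OC)c(OC)c(OC)c2)cc1`: 5 nM
Compound 3, `COc1ccccc1-c1ncnn1-c1cc(OC)c(OC)c(OC)c1`: > 10000 nM

The three were tested in a functional assay on Jurkat cells (Homo sapiens) for antiproliferative activity, read by MTT assay, with a stated time of 72 h; on this read-out lower numbers stand for stronger inhibition and higher numbers for weaker inhibition. Compound 1 gives 50 nM in this assay. Compound 2 differs from compound 1 by methyl in place of hydrogen on a saturated chain carbon bound to an oxygen on an aromatic ring, and this single change brings a 10-fold lower number from compound 1 to compound 2 (1.00 log units; beyond the scatter). Compound 3 shares the same atoms as compound 1 but differs by 2-methoxyphenyl in place of 4-methoxyphenyl on an aromatic carbon. For compound 3 this assay reports only a limit, > 10000 nM, so that its number is not known. Measured against compound 1, this reads as an at least 200-fold higher number from compound 1 to compound 3 (2.30 log units; beyond the scatter), a step whose true size cannot be fixed because of the limit of > 10000 nM in this assay, at which 1 of the 3 values shown sits.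

Compound 4, `CCOc1ccccc1-c1ncnn1-c1cc(OC)c(OC)c(OC)c1`, has not been measured. It differs from compound 3 by methyl in place of hydrogen on a saturated chain carbon bound to an oxygen on an aromatic ring, the same change that separates compound 2 from compound 1, made at the same place. Compound 4 is expected to show an at least 1.2-fold lower number from compound 3 to compound 4 (0.09 log units; that floor lies within the scatter) in this assay. That expectation rests on a 10-fold lower number from compound 1 to compound 2 (1.00 log units; beyond the scatter), which shows what the change achieved once, and on (the limit of > 10000 nM in this assay, at which 1 of the 3 values shown sits), which leaves compound 3 without a number to start from, so that even a step of similar size could leave compound 4 at the limit of the assay. Compound 4 is therefore estimated at 8000 nM, with the range 1500 nM to 30000 nM.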

Compound 4, half-maximal inhibitory concentration: > 10000 nM
Compound 4: no number, only a limit; the forecaster's own chance of this, stated with the estimate: 50%; middle value at least 1.2-fold (0.09 log units) away from the limit.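

In this assay compound 4 gives > 10000 nM, which is a limit and not a number. No step can be read between compound 3 and compound 4, because both stand at a limit: the limit of > 10000 nM in this assay, at which 2 of the 4 values shown sit.

The compounds shown leave open whether the change from methoxy to ethoxy alters the activity of compound 3 at all, and what the true values of compound 3 and compound 4 are.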